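A few compounds are considered here, and "the series" means these few. Any claim that something is new, unique, unknown or untested is made for them only; others in the source may bear on it.

Series notes. In an assay on CHO cells for displacement of a labelled ligand from adenosine receptor A3 (Homo sapiens), read by scintillation counting, with a stated time of 60 min, tested at 1 uM (on this read-out higher numbers stand for more inhibition at the one concentration tested (going by the name of the read-out) and lower numbers for less inhibition), compound 1 `Cc1nc(NC(=O)NCc2ccccc2)c2nn(-c3ccccc3)cc2n1` gives 1%, so the one concentration tested leaves the labelled ligand essentially in place. Compound 2 `COc1ccc(-n2cc3nc(C)nc(NC(=O)Nc4ccccc4)c3n2)cc1` stands level with compound 1 at the digits printed: in this assay compound 2 gives 1%, and the gap to compound 1 lies within the usual scatter, so no order between the two can be read from these numbers.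

Compound 3 `COc1ccc(-n2cc3nc(C)nc(NC(=O)NCc4ccccc4)c3n2)cc1` is the next member to be tested. It differs from compound 2 in one place: benzyl in place of phenyl on an amide-type nitrogen. The same exchange, cut one bond further out, reads anilino to benzylamino. Among the compounds with values here, compound 1 already carries the benzyl on the amide-type nitrogen and sits at the bottom of the read-out, which is the only guide available here; no measured step describes this exchange directly.

On that basis the step from compound 2 to compound 3 is expected to be a number 1 percentage points higher from compound 2 to compound 3 (within the scatter), that is, none beyond the scatter. The estimate for compound 3 in this assay is 2%, with a range from 0% to 12%.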

Compound 3, a percentage reported as inhibition, at one concentration (the size of the read-out at that concentration, not a potency): 6%
Estimate against measurement, compound 3: 4 percentage points below; the range from low to high includes it.
By their numbers in this assay, from the lowest: compounds 1, 2 and 3 (each within the scatter of the next).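

In this assay, within the data shown here, benzyl in place of phenyl on an amide-type nitrogen gives a number 5 percentage points higher from compound 2 to compound 3 (within the scatter) and thus the first direct reading of this exchange, made with the methoxy group held in place. Among these compounds, with benzyl held on the amide-type nitrogen, methoxy in place of hydrogen on an aromatic carbon gives a number 5 percentage points higher from compound 1 to compound 3 (within the scatter) and so supplies the first reading at this second position. Neither exchange separates its pair on this read-out at the one concentration tested, and no information at hand bears on the reason for this.

The three compounds therefore leave open whether either position can affect displacement of the labelled ligand in this assay at all, since these values give no order among compounds 1, 2 and 3. Still open, as far as these compounds go, is whether a longer chain such as phenethyl on the amide-type nitrogen, or a carboxylic acid or an amine in place of the methoxy group, would give a step beyond the scatter.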